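Trading a tert-butylpiperidine for piperazine on the propyl chain

The compounds below may be only part of what the source reports. "The series", "measured", "known", "first", "only" and "open" are said of these compounds alone.

Three compounds share one core and differ only in the basic group that hangs from an oxygen on an aromatic ring. Compound 1 `Clc1ccc(Oc2ccc3nc(-c4ccc(OCC5CCNCC5)cc4)oc3c2)cc1` is the shortest-chained of them; in an assay on isolated protein for inhibition of advanced glycosylation end product-specific receptor (Homo sapiens), read by FRET, with stated times of 30 min and 1 h, tested at 4 uM (on this read-out higher numbers stand for more inhibition at the one concentration tested (going by the name of the read-out) and lower numbers for less inhibition), compound 1 was reported as "not active" (no number reported). Compound 2 `CC(C)(C)C1CCN(CCCOc2ccc(-c3nc4ccc(Oc5ccc(Cl)cc5)cc4o3)cc2)CC1` carries a three-carbon chain ending in a 4-(tert-butyl)piperidin-1-yl group, and in this assay compound 2 gives 16.6%. Among the measured compounds shown here, that is the only number in this set, so compound 2 stands alone as the single measured point, with one further entry that has no number at all.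

Compound 3 `Clc1ccc(Oc2ccc3nc(-c4ccc(OCCCN5CCNCC5)cc4)oc3c2)cc1` keeps the three-carbon chain of compound 2 but changes the ring at its end: piperazin-1-yl in place of 4-(tert-butyl)piperidin-1-yl on a saturated chain carbon, three bonds along the chain from an oxygen on an aromatic ring.

For the measured compounds named here, no pair of measured compounds shows this kind of step, so there is nothing to calibrate against. With compound 1 reported as "not active" (no number reported) and compound 2 already low, the expected step of a number 7.6 percentage points lower from compound 2 to compound 3 (within the scatter) is small and downward, and may well sit within the scatter. Compound 3 is therefore estimated to give 9% in this assay, with a likely range from 0% to 20%.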

Compound 3, a percentage reported as inhibition, at one concentration (the size of the read-out at that concentration, not a potency): 42.7%
Beside the measured number, compound 3's estimate is 33.7 percentage points below it, outside the stated range (above it).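

In this assay, the group at the end of the chain turns out to matter at this position: the change gives a number 26.1 percentage points higher from compound 2 to compound 3 (beyond the scatter), a shift larger than repeat measurements would normally produce. Piperazin-1-yl differs from 4-(tert-butyl)piperidin-1-yl in several ways at once, with fewer heavy atoms, 2 ring nitrogens rather than 1, and 1 hydrogen-bond donor rather than 0, so this single step cannot separate their contributions. Nothing available here explains why the number rises.

Plain piperidin-1-yl on the same chain would help to separate the loss of the tert-butyl group from the gain of the second ring nitrogen, while 4-methylpiperazin-1-yl and morpholin-4-yl would show whether that nitrogen needs its hydrogen or can be capped or replaced by oxygen. As far as these compounds go, a longer chain ending in piperazin-1-yl also remains open, as does whether this gain at one tested concentration would carry over to a full measure of potency.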